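Replacing the nitro group of compound 1

This account rests on a few compounds, and the source may have more. Where it says the series, first, only, none or still open, it means among the compounds named here.

Measured in a functional assay on DU-145 cells (Homo sapiens) for cytotoxicity, read by trypan blue exclusion, with a stated time of 96 h; on this read-out lower numbers stand for stronger inhibition and higher numbers for weaker inhibition:
Compound 1 `COc1cc(OC)c(/C=C/S(=O)(=O)Cc2ccc(OC)c([N+](=O)[O-])c2)c(OC)c1`: 2500 nM
Compound 2 `COc1ccc(CS(=O)(=O)/C=C/c2c(OC)cc(O)cc2OC)cc1[N+](=O)[O-]`: 5000 nM
Compound 3 `COc1cc(OC)c(/C=C/S(=O)(=O)Cc2ccc(F)c([N+](=O)[O-])c2)c(OC)c1`: 25000 nM

Compound 1 belongs with the best of these three numbers, though it cannot be separated from compound 2: the measured step is a 2.0-fold higher number from compound 1 to compound 2 (0.30 log units; within the scatter). Compound 3 stands clearly apart, with a 10-fold higher number from compound 1 to compound 3 (1.00 log units; beyond the scatter).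

Compound 4 `COC(=O)C(F)(F)Nc1cc(CS(=O)(=O)/C=C/c2c(OC)cc(OC)cc2OC)ccc1OC` keeps the core of compound 1 but carries (difluoro(methoxycarbonyl)methyl)amino in place of nitro on an aromatic carbon, ortho to a methoxy group: (difluoro(methoxycarbonyl)methyl)amino in place of nitro on an aromatic carbon. Among the compounds with values here, all three measured compounds carry the nitro group, so no measured step shows what replacing it does. The closest evidence is a 10-fold higher number from compound 1 to compound 3 (1.00 log units; beyond the scatter), where fluoro takes the place of that same methoxy group. This shows that a single change on this part of the molecule can move the number in this assay beyond the scatter. The step of a 2.0-fold higher number from compound 1 to compound 2 (0.30 log units; within the scatter) lies elsewhere and adds little.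

The data do not settle the direction, but the expectation leans towards a lower number. The expected change is an 8.3-fold lower number from compound 1 to compound 4 (0.92 log units; beyond the scatter). For compound 4 the estimated value is 300 nM, with an expected range from 25 nM to 3000 nM.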

Compound 4, half-maximal inhibitory concentration: 250 nM
Estimate against measurement, compound 4: 1.2-fold (0.08 log units) above; the range from low to high includes it.
By their numbers in this assay, from the lowest: compound 4; then compounds 1 and 2 (each within the scatter of the next); then compound 3.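

In this assay, within the data shown here, the nitro group proves not to be needed for activity on these cells, since the earlier compounds all carried it and left that question untested, whereas its removal here gives a step beyond the scatter (a 10-fold lower number from compound 1 to compound 4 (1.00 log units; beyond the scatter)). This position, on an aromatic carbon ortho to a methoxy group, also accepts a group with more heavy atoms than nitro, one that adds a hydrogen-bond donor and keeps no nitrogen-oxygen double bond, without any loss in this assay. Nothing given here explains the size or direction of this step, so it stands as an observation about this one pair.

The compounds shown leave open which part of (difluoro(methoxycarbonyl)methyl)amino carries the change, since the group enters as a whole and a simple amine at this position, or a carboxylic acid in place of its methyl ester, would separate those parts. They also leave open whether a longer chain on the nitrogen or a different group in place of the two fluorines would move the number further, and whether the step would hold on another cell line.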